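Aromatic group swaps on the shared core

A few compounds are considered here, and "the series" means these few. Any claim that something is new, unique, unknown or untested is made for them only; others in the source may bear on it.

Measured in a physicochemical assay for pharmacokinetics, at pH 8; on this read-out higher numbers stand for a longer-lived compound and lower numbers for a shorter-lived compound:
- compound 1 `O=C(Sc1cccnc1C(=O)O)c1cccc(Cl)c1` gives 14.8 h
- compound 2 `O=C(Sc1cccnc1C(=O)O)c1cccc(C(F)(F)F)c1` gives 10 h

Not yet measured: compound 3 `COc1cccc(C(=O)Sc2cccnc2C(=O)O)c1`

Going by the values given here, compound 2 sits within the scatter of compound 1, the only other measured compound. Compound 3 has methoxy in place of trifluoromethyl on an aromatic carbon, meta to a large group (methoxy in place of trifluoromethyl on an aromatic carbon). Among the compounds with values here, one measured step bears on this, also a swap of groups on an aromatic carbon, and it is small (a 1.5-fold lower number from compound 1 to compound 2 (0.17 log units; within the scatter)). Within the data shown here, with only that step as a guide, no change beyond the scatter is expected (a 1.2-fold higher number from compound 2 to compound 3 (0.08 log units; within the scatter)). Compound 3 is estimated at 12 h (expected range 6 h to 24 h).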

Compound 3, half-life: 63.7 h
The estimate for compound 3 lay 5.3-fold (0.72 log units) below the measured number, and the stated range ends below it.
By their numbers in this assay, from the lowest: compounds 2 and 1 (each within the scatter of the next); then compound 3.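

In this assay, this position is sensitive to the group it carries: methoxy in place of trifluoromethyl raises the half-life (a 6.4-fold higher number from compound 2 to compound 3 (0.80 log units; beyond the scatter)), and methoxy in place of chloro also raises it (a 4.3-fold higher number from compound 1 to compound 3 (0.63 log units; beyond the scatter)). The earlier swap between chloro and trifluoromethyl stayed within the scatter and gave no sign of this. Nothing at hand accounts for the rise.

Still open, going by these compounds, is whether the rise is particular to methoxy or is shared by an amine, a hydroxyl or a longer chain such as ethoxy on the same aromatic carbon.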